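The source may hold more compounds than are shown below. What is called first, only, known or untested is meant among the compounds shown, and "the series" means these compounds.

Three compounds share one core, and in an ADME assay on microsomes from liver (Mus musculus, strain CD1) for metabolic stability, read by LC-MS, using NADPH, with a stated time of 60 min (a lower number here means that the compound disappears faster, a higher number that the compound lasts longer), compound 1 `N=c1c2c(-c3ccccc3)c(-c3ccccc3)n(Cc3ccccc3)c2ncn1C1CCN(Cc2ccccc2)CC1` gives 0.537 h, compound 2 `N=c1c2c(-c3ccccc3)c(-c3ccccc3)n(CC3CC3)c2ncn1CC1CCOCC1` gives 0.272 h, and compound 3 `COc1ccc(Cn2c(-c3ccccc3)c(-c3ccccc3)c3c(=N)n(CC4CCOCC4)cnc32)cc1` gives 0.217 h. Compound 3 sits within the scatter of compound 2, while compound 1 lies beyond the scatter above it. Among the measured compounds shown here, the only single change among the measured compounds is a 1.3-fold lower number from compound 2 to compound 3 (0.10 log units; within the scatter), a step that lies within the scatter and concerns the other chain on the core.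

Compound 4 `COc1ccc(Cn2c(-c3ccccc3)c(-c3ccccc3)c3c(=N)n(CCO)cnc32)cc1` differs from compound 3 by hydroxymethyl in place of oxan-4-yl on a saturated chain carbon bound to an aromatic nitrogen. For the measured compounds named here, no measured step touches that chain, and the change from compound 2 to compound 3 at the other chain moved the half-life in this assay by only a small amount. The number for compound 4 in this assay is therefore expected to stay close to that of compound 3, with a 1.2-fold higher number from compound 3 to compound 4 (0.06 log units; within the scatter) as the expected step and no change beyond the scatter. The half-life of compound 4 is estimated at 0.25 h, with a range from 0.12 h to 0.55 h.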

Compound 4, half-life: 0.518 h
The estimate for compound 4 lay 2.1-fold (0.32 log units) below the measured number; the range from low to high includes it.
By their numbers in this assay, from the lowest: compounds 3, 2, 4 and 1 (each within the scatter of the next, the first and the last beyond it).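

Among the compounds shown here, at the saturated chain carbon bound to an aromatic nitrogen, a position no earlier step had touched, hydroxymethyl in place of oxan-4-yl gives a 2.4-fold higher number from compound 3 to compound 4 (0.38 log units; beyond the scatter) in this assay. This is the first single change among these compounds that lies beyond the scatter, whereas the step at the other chain, a 1.3-fold lower number from compound 2 to compound 3 (0.10 log units; within the scatter), stayed within it. Nothing at hand accounts for the longer half-life of compound 4.

This one pair cannot show whether the step goes with the loss of the ring or with the arrival of the hydroxymethyl group, a question that a 2-methoxyethyl or a plain ethyl chain at this position would address. It also leaves open whether an amine at the end of the chain would behave like the hydroxymethyl group, and whether the step holds with cyclopropyl at the other chain.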